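Swapping the substituted phenyl for naphthyl on the shared core

A few compounds are considered here, and "the series" means these few. Any claim that something is new, unique, unknown or untested is made for them only; others in the source may bear on it.

Measured so far:
compound 1 `COc1ccc(CN2C(=O)C(=O)c3cc(-c4ccc(F)c(Cl)c4)ccc32)cc1` — > 10000 nM
compound 2 `COc1ccc(CN2C(=O)C(=O)c3cc(-c4ccc(C(F)(F)F)cc4)ccc32)cc1` — 820 nM

Of the compounds shown here, two with the same core have been tested in a functional assay on HepG2 cells (Homo sapiens) for antiproliferative activity, read by MTT assay, with a stated time of 48 h; a lower number here means a stronger inhibitor, a higher number a weaker inhibitor. For compound 1 only a limit is reported, > 10000 nM, so no number is known for it. For the measured compounds named here, compound 2 is the only compound with a true number, 820 nM. Going by the values given here, the single measured step, an at least 12-fold lower number from compound 1 to compound 2 (1.08 log units; beyond the scatter), rests on (the limit of > 10000 nM in this assay, at which 1 of the 2 values shown sits), so only its lower bound is known; it shows that the aryl group attached to the core can change the result strongly.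

Compound 3 `COc1ccc(CN2C(=O)C(=O)c3cc(-c4ccc5ccccc5c4)ccc32)cc1` has not yet been measured. It differs from compound 2 by naphthalen-2-yl in place of 4-(trifluoromethyl)phenyl on an aromatic carbon. Among the compounds with values here, no measured step covers a change of this kind, so the only guidance is that the aryl group matters, as the step from compound 1 to compound 2 shows. Compound 3 is therefore expected to stay near compound 2, with an estimated 1500 nM in this assay, in a range from 300 nM to 10000 nM. The expected step of a 1.8-fold higher number from compound 2 to compound 3 (0.26 log units; within the scatter) is small but carries wide uncertainty.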

Compound 3, half-maximal inhibitory concentration: > 10000 nM
Compound 3: a limit, no number (the forecaster's own chance of this, stated with the estimate: 25%); at least 6.6-fold (0.82 log units) between middle value and limit.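

In this assay, putting naphthalen-2-yl where 4-(trifluoromethyl)phenyl stood gives an at least 12-fold higher number from compound 2 to compound 3 (1.08 log units; beyond the scatter), so this aromatic carbon tolerates the first group but not the second, and the measurable activity of compound 2 does not carry over. The two groups have the same count of heavy atoms and neither has a hydrogen-bond donor or acceptor, so these counts do not separate them; they differ in having one aromatic ring with three fluorine atoms or two aromatic rings of carbon only, and among the three compounds only compound 2 gives a true number. Compound 1 and compound 3 each give a limit and not a number, so the step between them cannot be read: the limit of > 10000 nM in this assay, at which 2 of the 3 values shown sit.

These compounds leave open whether a plain phenyl, a 4-methoxyphenyl or a 4-cyanophenyl at this carbon would give a measurable value, and so whether the trifluoromethyl group itself matters. The rest of the molecule is the same in all three compounds, so they say nothing about how changes elsewhere on the shared core would act.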